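The source may hold more compounds than are shown below. What is called first, only, known or untested is meant among the compounds shown, and "the series" means these compounds.

Measured in a functional assay on SK-OV-3 cells (Homo sapiens); a lower number here means a stronger inhibitor of growth, a higher number a weaker inhibitor of growth:
- Compound 1 `O=S(=O)(/C=C/c1ccccc1)Cc1ccc(Nc2ncnc3ccccc23)cc1`: 5000 nM
- Compound 2 `O=S(=O)(/C=C/c1ccc(F)cc1Cl)Cc1ccc(Nc2ncnc3ccccc23)cc1`: 44000 nM

Of these two, compound 2 has the higher number and is the weaker inhibitor of growth. Compound 3 `O=S(=O)(/C=C/c1ccc(F)cc1Cl)Cc1ccc(Nc2ncnc3cc(Cl)ccc23)cc1` differs from it by chloro in place of hydrogen on an aromatic carbon of a fused system of two rings. Among the compounds with values here, the only measured step, an 8.8-fold higher number from compound 1 to compound 2 (0.94 log units; beyond the scatter), involves a different part of the molecule. It therefore gives only a loose guide to size and no direction for this change. In this assay, the estimated step is a 1.3-fold lower number from compound 2 to compound 3 (0.10 log units; within the scatter), and none beyond the scatter is expected. Compound 3 is expected at 35000 nM, with an estimated range of 9000 nM to 100000 nM.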

Compound 3, concentration for 50% growth inhibition: > 100000 nM
Compound 3: no number, only a limit; the forecaster's own chance of this, stated with the estimate: 15%; at least 2.8-fold (0.45 log units) between middle value and limit.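

Compound 3 gives > 100000 nM in this assay, which is a limit of the assay and not a number. Of the compounds shown, only this pair differs on the fused system of two rings, where chloro in place of hydrogen gives an at least 2.2-fold higher number from compound 2 to compound 3 (0.35 log units; beyond the scatter), so this change weakens growth inhibition on this scaffold rather than leaving it unchanged. How large the step really is stays unknown: the limit of > 100000 nM in this assay, at which 1 of the 3 values shown sits.

From the compounds shown here alone, whether a fluoro or methoxy group on the same aromatic carbon would act like chloro remains open. So does whether chloro there would have the same effect on compound 1.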